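Benzoxazole series: pyrrolidin-1-yl in place of anilino

The source may hold more compounds than are shown below. What is called first, only, known or untested is meant among the compounds shown, and "the series" means these compounds.

The compounds share one core and differ in the amine on it and in the pendant group; all were read in an assay on HEK293 cells for inhibition of Fatty-acid amide hydrolase 1 (Homo sapiens), read by fluorescence; a higher number here means a weaker inhibitor, a lower number a stronger inhibitor. For compound 1 `c1ccc(-c2ccc3oc(NC4CCCCC4)nc3c2)cc1` the result is only a limit of the assay, > 1000 nM. Compound 2 `Cn1ncc2c(-c3ccc4oc(NC5CCCCC5)nc4c3)cccc21` gives 52 nM in this assay. Compound 3 `Cn1ccc2cc(-c3ccc4oc(Nc5ccccc5)nc4c3)ccc21` gives 48 nM in this assay. Of the two values that are numbers rather than limits, compound 3 has the lower one, but compound 2 sits within the scatter of it, so the two are not separated by the data. Within the data shown here, no two measured compounds differ in a single place, so no step size is established.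

Compound 4 `Cn1ccc2cc(-c3ccc4oc(N5CCCC5)nc4c3)ccc21` is compound 3 with pyrrolidin-1-yl in place of anilino on an aromatic carbon; one hydrogen-bond donor leaves and none enters. In this assay, among the measured compounds shown here, the expected change is a 3.1-fold higher number from compound 3 to compound 4 (0.49 log units; beyond the scatter), a weakening somewhat beyond the scatter but well short of the limit of the assay, though the data give no measured step on which to anchor it. Compound 4 is accordingly estimated at 150 nM, with a likely range from 40 nM to 600 nM.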

Compound 4, half-maximal inhibitory concentration: 674 nM
Estimate against measurement, compound 4: 4.5-fold (0.65 log units) below; measured number above the stated range.
By their numbers in this assay, from the lowest: compounds 3 and 2 (each within the scatter of the next); then compound 4. At a limit, above all of these: compound 1.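

In this assay, among these compounds, this is the first measured single-place step: on the aromatic carbon next to the ring nitrogen and next to the ring oxygen, pyrrolidin-1-yl in place of anilino gives a 14-fold higher number from compound 3 to compound 4 (1.15 log units; beyond the scatter), so the number at this position does depend on which amine is attached. The change removes the hydrogen-bond donor and the six-membered aromatic ring of anilino together, and this single step cannot show which of the two accounts for the difference. Compound 4 still gives a number rather than a limit, so the step has a measured size and is not merely bounded, with the ceiling of the assay as follows: the limit of > 1000 nM in this assay, at which 1 of the 4 values shown sits.

Going by these compounds, it remains open whether methyl(phenyl)amino, which keeps the aromatic ring but carries no amine hydrogen, would stay close to compound 3 or move towards compound 4. Among the compounds shown here, also open is how cyclohexylamino behaves on the pendant group of compound 3: compounds 1 and 2 carry that amine on other pendant groups, and no single-place pair connects them with compounds 3 and 4.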